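The source may hold more compounds than are shown below. What is called first, only, known or untested is meant among the compounds shown, and "the series" means these compounds.

Within the data shown here, in a functional assay (trachea) with Cavia porcellus as the target (a lower number here means that less compound is needed, a higher number that more compound is needed for the effect), compound 1 `CCCn1c(=O)n(CCCCC(C)=O)c(=O)c2[nH]cnc21` gives 60 nM, the only number so far. Compound 2 `CCCn1c(=O)n(C)c(=O)c2c1ncn2CCC(=O)O` reads > 100000 nM, which is a limit of the assay. Compound 3 `CCCn1c(=O)n(C)c(=O)c2c1ncn2CC(N)=O` reads > 100000 nM, which is also a limit and not a number. Compound 3 therefore stands at the limit of > 100000 nM in this assay, at which 2 of the 3 values shown sit, and compound 2 is the other compound there.

Compound 4 `CCCn1c(=O)n(C)c(=O)c2c1ncn2CCO` has hydroxymethyl in place of the carbamoyl of compound 3, on a saturated chain carbon bound to an aromatic nitrogen: hydroxymethyl in place of carbamoyl on a saturated chain carbon bound to an aromatic nitrogen. Read one bond further out, this is carbamoylmethyl to 2-hydroxyethyl.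

Among the measured compounds shown here, the only measured step at this place is a step that the two limits leave unreadable from compound 2 to compound 3. It has no readable size, so it gives no measure for the new change. For the measured compounds named here, compound 3 differs from compound 1 in more than one place, so compound 1 at 60 nM sets no size for this step either. With both compounds that vary this chain at the limit, compound 4 is expected to stay close to that limit in this assay, with no clear move in either direction. The estimated change is a number no higher from compound 3 to compound 4 (the limit leaves the size open). For compound 4 the expected value is 100000 nM, with an estimated range from 30000 nM to 300000 nM.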

Compound 4, half-maximal effective concentration: 31800 nM
Compound 4: the middle estimate sits 3.1-fold (0.50 log units) above what was measured; the range from low to high includes it.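

In this assay, among these compounds, compound 4 gives the first number for a compound with a group on this chain at the aromatic nitrogen, and the 2-hydroxyethyl chain gives the change a readable direction: an at least 3.1-fold lower number from compound 3 to compound 4 (0.49 log units; beyond the scatter), and an at least 3.1-fold lower number from compound 2 to compound 4 (0.49 log units; beyond the scatter). Both steps start from a limit, leaving their full size open, and the step between compound 2 and compound 3 cannot be read. Within these three compounds, hydroxy at the chain end separates from both the carboxy of compound 2 and the carbamoyl of compound 3, which remain together at the limit: the limit of > 100000 nM in this assay, at which 2 of the 4 values shown sit.

Compound 1 gives 60 nM but differs from compound 4 in more than one place, so the compounds shown do not tell how much of the difference in their values belongs to this chain. Also open, going by these compounds, is how an amine at the chain end, or a longer chain ending in hydroxy, would read in this assay on the core of compound 4.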